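The source may hold more compounds than are shown below. What is called first, only, known or untested is meant among the compounds shown, and "the series" means these compounds.

Compound 2 `Cc1ccc(OC(=O)Nc2ccc([Se]C#N)cc2)cc1` gives 72000 nM in a functional assay on CCRF-CEM cells (Homo sapiens) for cytotoxicity, read by MTT assay, with a stated time of 72 h (on this read-out lower numbers stand for higher toxicity in this test and higher numbers for lower toxicity in this test), and it stands level with compound 1 `COc1ccc(OC(=O)Nc2ccc([Se]C#N)cc2)cc1`, which gives 70000 nM; the step of a 1.0-fold higher number from compound 1 to compound 2 (0.01 log units; within the scatter) lies within the scatter. Compound 3 `N#C[Se]c1ccc(NC(=O)Oc2ccc(Cl)cc2)cc1` differs from compound 2 by chloro in place of methyl on an aromatic carbon. Among the measured compounds shown here, the only step that bears on this change is that one at the same position, and it was flat, so no shift beyond the scatter is expected from compound 2 to compound 3 in this assay. The estimate for compound 3 is therefore 72000 nM, ranging from 35000 nM to 145000 nM, an expected step of no change at the digits printed from compound 2 to compound 3 (within the scatter).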

Compound 3, concentration lethal to 50% of the cells: 71800 nM
Compound 3: the middle estimate sits 1.0-fold (0.00 log units) above what was measured; low and high end bracket the measured number.
By their numbers in this assay, from the lowest: compounds 1, 3 and 2 (each within the scatter of the next).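

The step of a 1.0-fold lower number from compound 2 to compound 3 (0.00 log units; within the scatter) and the step of a 1.0-fold higher number from compound 1 to compound 3 (0.01 log units; within the scatter) place chloro alongside methyl and methoxy at this position, para to a large group. In this assay the three groups therefore cannot be told apart, and this flat reading now covers a halogen as well as carbon-linked and oxygen-linked groups. Nothing available here explains why they read alike. The compounds shown leave open whether an amine, a carboxylic acid or a longer chain at this position would move the number beyond the scatter. They also leave open whether a change elsewhere on the shared core would do so.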